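This account rests on a few compounds, and the source may have more. Where it says the series, first, only, none or still open, it means among the compounds named here.

Two compounds of this series have numbers in an assay on isolated protein for inhibition of aldehyde dehydrogenase 1A1 (Homo sapiens); on this read-out lower numbers stand for stronger inhibition and higher numbers for weaker inhibition. Compound 1 `Cn1ncc2c(=O)n(-c3ccccc3)c(/C=C/c3cccc(F)c3)nc21` gives 270 nM in this assay. Compound 2 `CC(Sc1nc2c(cnn2C)c(=O)n1-c1ccccc1)c1cccc(F)c1` gives 151 nM in this assay. These two numbers lie within the scatter of each other, so neither compound can be placed ahead of the other on this read-out. The step followed here leads from compound 2 to compound 3 `CC(Sc1nc2c(cnn2C)c(=O)n1-c1ccccc1)c1ccccc1`, which is not yet measured in this assay. The change is hydrogen in place of fluoro on an aromatic carbon; the fluoro leaves from an aromatic carbon of a six-membered aromatic ring of carbon only, meta to a large group, and a hydrogen enters there. For the measured compounds named here, no pair of measured compounds differing in one place exists, so the size of such a step cannot be read from the data. Only a fluoro leaves and a hydrogen enters. The expected step is no larger than the scatter, leaning if anything toward a higher number, and the step expected is a 1.7-fold higher number from compound 2 to compound 3 (0.22 log units; within the scatter). Compound 3 is estimated at 250 nM in this assay, expected to fall between 100 nM and 650 nM.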

Compound 3, half-maximal inhibitory concentration: 130 nM
Compound 3: the middle estimate sits 1.9-fold (0.28 log units) above what was measured, and the stated range covers the measured number.
By their numbers in this assay, from the lowest: compounds 3, 2 and 1 (each within the scatter of the next, the first and the last beyond it).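

In this assay, for the compounds shown here, the only pair differing in one place gives a 1.2-fold lower number from compound 2 to compound 3 (0.07 log units; within the scatter). At this aromatic carbon, meta to a large group, fluoro and hydrogen therefore cannot be told apart on this read-out, and the fluoro of the 3-fluorophenyl group is not required for a number of this size in this pair. This reading rests on one pair and two substituents, and nothing beyond the values themselves bears on the result.

From the compounds shown here alone, whether methoxy, trifluoromethyl or an amine at the same carbon would give a step beyond the scatter remains open. Also open, going by these compounds, is what would follow if the 1-phenylethyl group gave way to a longer chain or one ending in a carboxylic acid.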